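Hydroxy to chloro: compound 2 to compound 3

A few compounds are considered here, and "the series" means these few. Any claim that something is new, unique, unknown or untested is made for them only; others in the source may bear on it.

Compound 1 `COc1ccc(C(=O)/C=C/c2cc3ccccc3[nH]c2=O)cc1` gives 91600 nM in an ADME assay on MDA-MB-435 cells (Homo sapiens) for cytotoxicity, read by sulforhodamine B assay, with a stated time of 24 h; a lower number here means that less compound is tolerated, a higher number that more compound is tolerated. Compound 2 `O=C(/C=C/c1cc2ccccc2[nH]c1=O)c1ccc(O)cc1` returns only an assay limit, > 100000 nM. The step of an at least 1.0-fold higher number from compound 1 to compound 2 (0.03 log units; that floor lies within the scatter) is therefore a floor that sits within scatter, and the limit of > 100000 nM in this assay, at which 1 of the 2 values shown sits, marks where compound 2 stands. Compound 3 `O=C(/C=C/c1cc2ccccc2[nH]c1=O)c1ccc(Cl)cc1` differs from compound 2 by chloro in place of hydroxy on an aromatic carbon. No measured step touches this change; the one step shown alters a group on an oxygen, not on the ring carbon. The number for compound 3 in this assay is expected to stay close, a step of an at least 1.2-fold lower number from compound 2 to compound 3 (0.09 log units; that floor lies within the scatter) within scatter. Compound 3 is thus estimated at 80000 nM, with a range from 30000 nM to 200000 nM.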

Compound 3, concentration lethal to 50% of the cells: > 100000 nM
Compound 3: only a limit was reported; the forecaster's own chance of this, stated with the estimate: 45%; at least 1.2-fold (0.09 log units) between middle value and limit.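

In this assay compound 3 also returns only a limit, so the change from 4-hydroxyphenyl to 4-chlorophenyl yields no number, and the step between compound 2 and compound 3 cannot be read. Within the data shown here, the one readable step, with chloro in place of methoxy, is an at least 1.0-fold higher number from compound 1 to compound 3 (0.03 log units; that floor lies within the scatter). Most of the series now rests on a limit rather than a number: the limit of > 100000 nM in this assay, at which 2 of the 3 values shown sit.

On these data alone, whether compound 2 and compound 3 differ at all remains open. Also open, as far as these compounds go, is whether an amine or a carboxylic acid on this ring carbon would give a readable number.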